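Capping a Hydroxy Group: From Compound 2 to Compound 3

A few compounds are considered here, and "the series" means these few. Any claim that something is new, unique, unknown or untested is made for them only; others in the source may bear on it.

compound 1, `COc1cc(Cl)cc(-c2nn(-c3cccc(NC(=O)c4ccc(Cl)c(Cl)c4)c3)cc2-c2ccncc2)c1`: 105%
compound 2, `O=C(Nc1cccc(-n2cc(-c3ccncc3)c(-c3cc(O)cc(Cl)c3)n2)c1)Nc1ccc(Cl)c(C(F)(F)F)c1`: 8.99%

In a functional assay on HOP-62 cells (Homo sapiens) for inhibition, read by sulforhodamine B assay, with a stated time of 48 h, tested at 10 uM (a lower number here means a stronger effect, a higher number a weaker effect of the compound at the concentration tested), compound 1 gives 105%, while compound 2 gives 8.99%. Compound 2 therefore holds the lower of the two numbers, and its distance from compound 1 lies well beyond the usual scatter; since the two compounds differ in more than one place, their values show no more than that.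

Compound 3, `COc1cc(Cl)cc(-c2nn(-c3cccc(NC(=O)Nc4ccc(Cl)c(C(F)(F)F)c4)c3)cc2-c2ccncc2)c1`, has not yet been measured. It differs from compound 2 in a single place: methyl in place of hydrogen on an oxygen on an aromatic ring. Among the compounds with values here, no pair of measured compounds isolates this change, so its weight is unknown here. Compound 1 does carry the methoxy group but differs elsewhere as well, and cannot settle the question. The step of a number 16 percentage points higher from compound 2 to compound 3 (beyond the scatter) is expected to be a modest weakening, close to the edge of the scatter. Compound 3 is accordingly estimated at 25%, within 5% to 70%.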

Compound 3, a percentage reported as activity, at one concentration (the size of the read-out at that concentration, not a potency): 13.5%
The estimate for compound 3 lay 11.5 percentage points above the measured number; low and high end bracket the measured number.
By their numbers in this assay, from the lowest: compounds 2 and 3 (each within the scatter of the next); then compound 1.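

In this assay, methyl in place of hydrogen on the oxygen gives a number 4.5 percentage points higher from compound 2 to compound 3 (within the scatter) and so leaves the effect within the scatter: at this place on the aromatic ring, hydroxy and methoxy cannot be told apart by this read-out. With the methoxy group held constant, the change on the carbonyl carbon, (4-chloro-3-(trifluoromethyl)phenyl)amino in place of 3,4-dichlorophenyl, gives a number 91.5 percentage points lower from compound 1 to compound 3 (beyond the scatter). This change thus accounts for the large gap that compound 1 and compound 2 alone could not assign to any one place. No supporting measurement is available to explain either step.

Going by these compounds, whether an ethoxy group, a longer chain on the oxygen or an amine in its place would keep the effect remains open. So does whether the match between hydroxy and methoxy holds at lower concentrations, where the read-out may separate compounds that look alike here.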